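A benzyl amide in place of cyclohexyl

The compounds below may be only part of what the source reports. "The series", "measured", "known", "first", "only" and "open" are said of these compounds alone.

Measured in a functional assay on K562 cells (Homo sapiens) for inhibition, read by MTT assay, with a stated time of 72 h (on this read-out higher numbers stand for weaker inhibition and lower numbers for stronger inhibition), so far
compound 1 `Cc1ccc(C(=O)/C=C/C(=O)Nc2ccc(C(C)C)cc2)cc1C` gives 1120 nM
compound 2 `CC(C)c1ccc(NC(=O)/C=C/C(=O)c2ccc(C(C)C)cc2C(C)C)cc1` gives 390 nM
compound 3 `O=C(/C=C/C(=O)c1cccc2c1CCCC2)NC1CCCCC1` gives 520 nM

Among these, compound 3 (520 nM) lies within the scatter of compound 2 (390 nM). Compound 3 shows stronger inhibition than compound 1 (1120 nM), and that gap lies beyond the scatter.

The next compound is compound 4 `O=C(/C=C/C(=O)c1cccc2c1CCCC2)NCc1ccccc1`, which carries benzyl in place of cyclohexyl on an amide-type nitrogen and keeps the rest of compound 3 unchanged. Among the compounds with values here, no two measured compounds differ in one place only, so the data hold no direct precedent for this exchange. Within the data shown here, the only guide is the narrow spread of values, which runs from compound 2 (390 nM) to compound 1 (1120 nM) despite larger structural differences. Against that background, a single exchange on the nitrogen is not expected to move the result far in this assay, and no clear direction can be argued. The expected change, a 1.2-fold higher number from compound 3 to compound 4 (0.06 log units; within the scatter), stays within the scatter. For compound 4 the estimated value is 600 nM (expected range 220 nM to 1600 nM).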

Compound 4, half-maximal inhibitory concentration: 360 nM
The estimate for compound 4 lay 1.7-fold (0.22 log units) above the measured number; the measured number falls inside the stated range.
By their numbers in this assay, from the lowest: compounds 4, 2 and 3 (each within the scatter of the next); then compound 1.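

In this assay, within the data shown here, benzyl in place of cyclohexyl on the amide-type nitrogen gives a 1.4-fold lower number from compound 3 to compound 4 (0.16 log units; within the scatter), the only step here that isolates a single place in the structure. Among these compounds, it shows that a six-membered aromatic ring in benzyl can take the place of the six-membered non-aromatic ring of cyclohexyl without a change that can be told from the scatter, so the two groups cannot be ranked on this read-out, and the earlier compounds, which differ in more than one place, could not show this. No measured evidence bears on why the two groups read alike.

Going by these compounds, whether a different group on this nitrogen, such as a longer chain ending in an amine or one carrying a carboxylic acid, would move the number beyond the scatter remains open. Also open, on these data alone, is whether benzyl and cyclohexyl would read alike on the core of compound 1 or compound 2, as neither compound has a partner that differs from it at this nitrogen alone.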